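This account rests on a few compounds, and the source may have more. Where it says the series, first, only, none or still open, it means among the compounds named here.

Compound 1 `Cc1cc(C)c(S(=O)(=O)N2CCC(C3OCC(C)CO3)CC2)c(C)c1` is the starting point of this comparison. In a functional assay on DLD-1 cells (Homo sapiens) for antiproliferative activity, read by CellTiter-Glo, with a stated time of 72 h (on this read-out lower numbers stand for stronger inhibition and higher numbers for weaker inhibition), compound 1 gives > 5000 nM, which is a limit of the assay rather than a number (the limit of > 5000 nM in this assay, at which 1 of the 3 values shown sits). Two related compounds with a different aromatic part have also been measured: compound 2 `CC1CCN(C2CCN(S(=O)(=O)c3cccc(-c4ccc(F)cc4)c3)CC2)CC1` gives 12 nM in this assay, and compound 3 `Cc1ccc(-c2ccccc2S(=O)(=O)N2CCC(N3CCC(C)CC3)CC2)cc1` gives 366 nM. Compound 4 `Cc1cc(C)c(S(=O)(=O)N2CCC(N3CCC(O)CC3)CC2)c(C)c1` is compound 1 with a single change (a group of 7 heavy atoms (5 carbon, 1 nitrogen, 1 oxygen; one six-membered non-aromatic ring with 1 hetero atom) in place of a group of 7 heavy atoms (5 carbon, 2 oxygen; one six-membered non-aromatic ring with 2 hetero atoms), on a saturated ring carbon). For the measured compounds named here, no measured pair shows exactly this change, so the expected step rests only on the values of compounds 2 and 3 against the limit of compound 1; a step toward stronger inhibition is expected, of size an at least 3.3-fold lower number from compound 1 to compound 4 (0.52 log units; beyond the scatter). Compound 4 is estimated at 1500 nM, between 300 nM and 6000 nM.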

Compound 4, half-maximal inhibitory concentration: 106 nM
Compound 4: middle estimate off by 14-fold (1.15 log units), on the high side; the measured number lies below the stated range.
By their numbers in this assay, from the lowest: compound 2; then compound 4; then compound 3. At a limit, above all of these: compound 1.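

Swapping the group on this saturated ring carbon for 4-hydroxypiperidin-1-yl gives an at least 47-fold lower number from compound 1 to compound 4 (1.67 log units; beyond the scatter) in this assay. The earlier compounds shown here also differed in their aromatic part, whereas here that part stays the same, so this change alone moves the read-out from a limit to a measured number. The full size of the step remains unknown, since the value of compound 1 is a limit: the limit of > 5000 nM in this assay, at which 1 of the 4 values shown sits.

The compounds shown do not separate the contribution of the new ring nitrogen from that of the hydroxyl. A plain piperidine, or a methoxy group in place of the hydroxyl, on the same core would help tell them apart.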